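A Longer Chain on Compound 3

The compounds below may be only part of what the source reports. "The series", "measured", "known", "first", "only" and "open" are said of these compounds alone.

Among the compounds with values here, compound 3 `CCCCCCCCCCCCNC(=O)[C@@H](NS(=O)(=O)c1cccs1)[C@@H](C)O` gives 22000 nM in a functional assay on A-431 cells (Homo sapiens) for cytotoxicity, read by MTT assay, with a stated time of 48 h (on this read-out lower numbers stand for stronger inhibition and higher numbers for weaker inhibition), the second highest of the three numbers measured so far. Compound 2 `CCCCCCCCCCCCNC(=O)[C@@H](NC(=O)c1cccs1)[C@@H](C)O` gives 16600 nM, a value within the scatter of compound 3, while compound 1 `CCCCCCCCCCCCNC(=O)[C@@H](NC(=O)c1ccco1)[C@@H](C)O` gives 92400 nM, as the step of a 4.2-fold lower number from compound 1 to compound 3 (0.62 log units; beyond the scatter) shows. Compound 4 `CCCCCCCCCCCCCCNC(=O)[C@@H](NS(=O)(=O)c1cccs1)[C@@H](C)O` differs from compound 3 by ethyl in place of hydrogen on a saturated chain carbon, ten or more bonds along the chain from an amide-type nitrogen. The measured steps, a 5.6-fold lower number from compound 1 to compound 2 (0.75 log units; beyond the scatter), a 4.2-fold lower number from compound 1 to compound 3 (0.62 log units; beyond the scatter) and a 1.3-fold higher number from compound 2 to compound 3 (0.12 log units; within the scatter), all alter the group on the amine nitrogen and leave the chain untouched, so none of them speaks directly to this change, and no step beyond the scatter is expected. The estimate for compound 4 is therefore 22000 nM, with a range of 8000 nM to 60000 nM, which corresponds to an expected step of no change at the digits printed from compound 3 to compound 4 (within the scatter).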

Compound 4, half-maximal inhibitory concentration: 22000 nM
Compound 4: the middle estimate sits on the measured number at the digits printed, and the stated range covers the measured number.
By their numbers in this assay, from the lowest: compounds 2, 3 and 4 (each within the scatter of the next); then compound 1.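

Within the data shown here, earlier steps all changed the group on the amine nitrogen, so this is the first look at the chain itself. Ethyl in place of hydrogen on a saturated chain carbon gives (no change at the digits printed from compound 3 to compound 4 (within the scatter)) in this assay, so at this far point on the chain, this added length leaves the number in place. No measurement here offers a reason for this.

Open, from the compounds shown here alone, is whether a much shorter chain, or a chain carrying an amine or a carboxylic acid, would move the number. The same added ethyl on compound 2 also remains to be read.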